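The source may hold more compounds than are shown below. What is called first, only, known or untested is meant among the compounds shown, and "the series" means these compounds.

Working notes on the series. Compound 1 `NS(=O)(=O)c1ccc2nc(N3N=C(c4ccc(Br)cc4)CC3c3ccc(Cl)cc3)sc2c1`, compound 2 `Cc1ccc(C2CC(c3ccc(Cl)cc3)=NN2c2nc3ccc(S(N)(=O)=O)cc3s2)cc1` and compound 3 `COc1ccc(C2CC(c3ccc(Cl)cc3)=NN2c2nc3ccc(S(N)(=O)=O)cc3s2)cc1` share one core and differ only in the group on the aromatic ring attached to the sp3 carbon. In a functional assay on the whole organism (strain Wistar) for inhibition, with Rattus norvegicus as the target, read by paw edema, with stated times of 1 h and 5 h, at a dose of 20 mg/kg by the oral route (on this read-out higher numbers stand for more inhibition at the one dose given (going by the name of the read-out) and lower numbers for less inhibition), compound 1 gives 14%, compound 2 gives 14% and compound 3 gives 67.7%. Compound 1 thus stands level with compound 2 at the digits printed, the two together at the bottom of the three numbers, while compound 3 sits well above both. For the measured compounds named here, the one single-point step measured, a number 53.7 percentage points higher from compound 2 to compound 3 (beyond the scatter), is large and lies on the same ring.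

Compound 4 `CN(C)c1ccc(C2CC(c3ccc(Br)cc3)=NN2c2nc3ccc(S(N)(=O)=O)cc3s2)cc1` is not yet measured. It differs from compound 1 by dimethylamino in place of chloro on an aromatic carbon, on the ring where the methyl-to-methoxy step acted. Going by the values given here, no measured step shows dimethylamino against chloro, so the bearing of the one known step is indirect; both changes bring in a hydrogen-bond acceptor at that place. An upward step is therefore expected, a number 26 percentage points higher from compound 1 to compound 4 (beyond the scatter), smaller than the known one and wide in range. Compound 4 is estimated at 40%, between 15% and 70%.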

Compound 4, a percentage reported as inhibition, in the whole organism at one dose (the size of the read-out at that dose, not a potency): 14%
For compound 4 the middle estimate is 26 percentage points above the measured one, outside the stated range (below it).
By their numbers in this assay, from the lowest: compounds 1, 2 and 4 (each within the scatter of the next); then compound 3.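

In this assay, going from 4-chlorophenyl to 4-(dimethylamino)phenyl gives no change at the digits printed from compound 1 to compound 4 (within the scatter), so this position does not answer to every replacement, whereas the earlier step gave a number 53.7 percentage points higher from compound 2 to compound 3 (beyond the scatter). The hydrogen-bond acceptor that dimethylamino brings in is thus not enough on its own in this pair, although the two steps rest on different backgrounds, with bromo on the other aromatic ring of compounds 1 and 4 and chloro on that of compounds 2 and 3. Nothing at hand gives a reason for the absence of change with dimethylamino.

From the compounds shown here alone, it remains open whether methoxy keeps its large step with bromo on the other aromatic ring. Going by these compounds, it is also open whether the higher number belongs to methoxy alone or extends to groups such as ethoxy or hydroxy at this place.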